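A few compounds are considered here, and "the series" means these few. Any claim that something is new, unique, unknown or untested is made for them only; others in the source may bear on it.

Of the compounds shown here, three that share one core have been measured in an assay on isolated protein for inhibition of proto-oncogene tyrosine-protein kinase receptor Ret variant V804M (Homo sapiens), read by 33P incorporation, with stated times of 15 min and 40 min; on this read-out higher numbers stand for weaker inhibition and lower numbers for stronger inhibition. Compound 1 `COc1ccc(NC(=O)Nc2ccc(Nc3ncnc4c3OCCN4)cc2)cc1` gives 824 nM, compound 2 `Cc1cc(C)cc(NC(=O)Nc2ccc(Nc3ncnc4c3OCCN4)cc2)c1` gives 971 nM, and compound 3 `O=C(Nc1ccc(Nc2ncnc3c2OCCN3)cc1)Nc1cc(Cl)cc(Cl)c1` gives 1300 nM. Compound 3 carries the highest of the three numbers, yet the steps of a 1.6-fold higher number from compound 1 to compound 3 (0.20 log units; within the scatter) and a 1.3-fold higher number from compound 2 to compound 3 (0.13 log units; within the scatter) both lie within the scatter, as does a 1.2-fold higher number from compound 1 to compound 2 (0.07 log units; within the scatter). Compound 4 `CC(C)(C)c1csc(NC(=O)Nc2ccc(Nc3ncnc4c3OCCN4)cc2)n1` is the next to be tested; it differs from compound 3 by 4-(tert-butyl)-1,3-thiazol-2-yl in place of 3,5-dichlorophenyl on an amide-type nitrogen. The measured steps exchanged one six-membered aromatic ring of carbon only for another, and none brought in a five-membered aromatic ring with 2 hetero atoms, so they offer only loose guidance. Every measured exchange on that nitrogen stayed within the scatter, and the step of no change at the digits printed from compound 3 to compound 4 (within the scatter) is expected to be small as well, in no clear direction. Compound 4 is therefore estimated at 1300 nM, with a likely range from 400 nM to 4000 nM.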

Compound 4, half-maximal inhibitory concentration: 5170 nM
For compound 4 the middle estimate is 4.0-fold (0.60 log units) below the measured one, and the stated range ends below it.
By their numbers in this assay, from the lowest: compounds 1, 2 and 3 (each within the scatter of the next); then compound 4.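

In this assay the 4-(tert-butyl)-1,3-thiazol-2-yl group gives a 4.0-fold higher number from compound 3 to compound 4 (0.60 log units; beyond the scatter) and a 5.3-fold higher number from compound 2 to compound 4 (0.73 log units; beyond the scatter) and also a 6.3-fold higher number from compound 1 to compound 4 (0.80 log units; beyond the scatter) on the amide-type nitrogen. Exchanges among the six-membered rings had stayed within the scatter, so this is the first sign that the position responds to what it carries, here with weaker inhibition. No measurement at hand explains the shift.

On these data alone, it remains open whether the five-membered ring or the tert-butyl group accounts for it. A plain 1,3-thiazol-2-yl group, or a phenyl ring carrying tert-butyl, would separate the two.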